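A few compounds are considered here, and "the series" means these few. Any claim that something is new, unique, unknown or untested is made for them only; others in the source may bear on it.

In a functional assay on Huh-7 cells (Homo sapiens) for cytotoxicity, read by MTT assay, with a stated time of 3 days (on this read-out higher numbers stand for lower toxicity in this test and lower numbers for higher toxicity in this test), compound 3 `CSCc1ncnc2c1ncn2[C@@H]1O[C@H](CO)[C@@H](O)[C@H]1O` gives only a limit, > 100000 nM. Compound 1 `CN(Cc1ccccc1)Cc1ncnc2c1ncn2[C@@H]1O[C@H](CO)[C@@H](O)[C@H]1O` gives a number in this assay, 9000 nM. Compound 2 `OC[C@H]1O[C@@H](n2cnc3c(CSc4ccccn4)ncnc32)[C@H](O)[C@@H]1O` likewise reaches only a limit in this assay, > 100000 nM. The step of an at least 11-fold higher number from compound 1 to compound 3 (1.04 log units; beyond the scatter) and the step of an at least 11-fold higher number from compound 1 to compound 2 (1.04 log units; beyond the scatter) both run from a number into the limit, while a step that the two limits leave unreadable from compound 2 to compound 3 cannot be sized because of the limit of > 100000 nM in this assay, at which 2 of the 3 values shown sit. Compound 4 `OC[C@H]1O[C@@H](n2cnc3c(Cn4cccn4)ncnc32)[C@H](O)[C@@H]1O` differs from compound 3 by 1H-pyrazol-1-yl in place of methylsulfanyl on a saturated chain carbon bound to an aromatic carbon. Within the data shown here, no measured step covers this particular change; the two steps that end at the limit leave compound 3 and its neighbours all at the upper edge of this assay. Compound 4 is therefore expected to give about 100000 nM, between 30000 nM and 300000 nM. The expected step is estimated as a number no higher from compound 3 to compound 4 (the limit leaves the size open).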

Compound 4, half-maximal cytotoxic concentration: > 250000 nM
Compound 4: only a limit was reported (the forecaster's own chance of this, stated with the estimate: 70%); middle value at least 2.5-fold (0.39 log units) away from the limit.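

In this assay compound 4 gives > 250000 nM, which is a limit of the assay. The result shows that a group bound through nitrogen on this saturated chain carbon is not enough to give a measurable number, as the step of an at least 27-fold higher number from compound 1 to compound 4 (1.44 log units; beyond the scatter) shows. Compound 1 remains the only one of the four with a number, and the steps among compound 2, compound 3 and compound 4 cannot be read: the limit of > 250000 nM in this assay, at which 1 of the 4 values shown sits.

From the compounds shown here alone, the order among those three compounds stays open. So does which part of benzyl(methyl)amino matters, which a smaller amine such as dimethylamino on the same carbon could test.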